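The source may report more compounds than this note shows. Statements on the series, on what has been measured and on what is new or still open speak of the compounds shown alone.

Measured compounds:
- compound 1 `Cc1ccccc1-c1nc2cc(-c3nc4cc(C#N)ccc4[nH]3)ccc2[nH]1`: 1200 nM
- compound 2 `N#Cc1ccc2[nH]c(-c3ccc4[nH]c(-c5ccc6ccccc6c5)nc4c3)nc2c1`: 130 nM

In a functional assay on RPMI 8402 cells (Homo sapiens) for cytotoxicity (on this read-out lower numbers stand for stronger inhibition and higher numbers for weaker inhibition), compound 1 gives 1200 nM, the highest of the two numbers; its nearest neighbour, compound 2, gives 130 nM, so that the step of a 9.2-fold lower number from compound 1 to compound 2 (0.97 log units; beyond the scatter) goes the other way from where compound 3 is headed. Compound 3 `Cc1ccccc1-c1nc2cc(-c3nc4cc(C(N)=O)ccc4[nH]3)ccc2[nH]1` differs from compound 1 in one place: carbamoyl in place of cyano on an aromatic carbon. Among the measured compounds shown here, the only measured step, from compound 1 to compound 2, changes a different part of the shared core, so no measured step bears directly on the exchange of cyano for carbamoyl. Without a comparable step, the expectation is that compound 3 stays close to compound 1, with no change beyond the scatter, and a 1.3-fold higher number from compound 1 to compound 3 (0.10 log units; within the scatter) is the estimated step. Compound 3 is therefore expected to give about 1500 nM in this assay, within 400 nM to 6000 nM.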

Compound 3, half-maximal inhibitory concentration: 8200 nM
Beside the measured number, compound 3's estimate is 5.5-fold (0.74 log units) below it, and the stated range ends below it.
By their numbers in this assay, from the lowest: compound 2; then compound 1; then compound 3.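

In this assay, the aromatic carbon that carries the cyano group of compound 1 turns out not to be a neutral place for change: carbamoyl in place of cyano gives a 6.8-fold higher number from compound 1 to compound 3 (0.83 log units; beyond the scatter), which means weaker inhibition. The number therefore responds at this place as well as at the other end of the shared core, where the earlier step was a 9.2-fold lower number from compound 1 to compound 2 (0.97 log units; beyond the scatter). Nothing available here explains why the carbamoyl group gives the higher number.

On these data alone, it remains open whether a carboxylic acid or an aminomethyl group on this aromatic carbon would give a number nearer that of compound 1 or that of compound 3. As far as these compounds go, it is also open whether carbamoyl in place of cyano would shift the number to a similar extent in compound 2, which carries naphthalen-2-yl.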